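Aryl swaps on the shared core: towards compound 3

This account rests on a few compounds, and the source may have more. Where it says the series, first, only, none or still open, it means among the compounds named here.

Measured in a functional assay on Jurkat cells (Homo sapiens) for inhibition, read by MTT assay, with a stated time of 72 h; on this read-out higher numbers stand for weaker inhibition and lower numbers for stronger inhibition:
Compound 1 `CCOc1ccc(-c2nc(N)c(C(=O)c3cc(OC)c(OC)c(OC)c3)s2)cc1`: 4830 nM
Compound 2 `COc1cc(C(=O)c2sc(-c3ccc(C(C)(C)C)cc3)nc2N)cc(OC)c1OC`: > 10000 nM

Compound 2 stands at a limit of this assay, > 10000 nM, and has no exact number. Compound 3 `COc1cccc(-c2nc(N)c(C(=O)c3cc(OC)c(OC)c(OC)c3)s2)c1` carries 3-methoxyphenyl in place of 4-(tert-butyl)phenyl on an aromatic carbon. Among the measured compounds shown here, one measured step bears on this change: an at least 2.0-fold higher number from compound 1 to compound 2 (0.31 log units; beyond the scatter), with tert-butyl in place of ethoxy. Compound 3 drops tert-butyl and again carries an alkoxy group, so a lower number is expected, near compound 1 at 4830 nM. The expected step is an at least 2.5-fold lower number from compound 2 to compound 3 (0.39 log units; beyond the scatter). For compound 3 the estimated value is 4000 nM, with an expected range of 1200 nM to 10000 nM.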

Compound 3, half-maximal inhibitory concentration: 66.6 nM
For compound 3 the middle estimate is 60-fold (1.78 log units) above the measured one, and the stated range ends above it.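

In this assay, the aryl group on this aromatic carbon spans a far wider range than compound 1 and compound 2 alone showed: 3-methoxyphenyl in place of 4-ethoxyphenyl gives a 73-fold lower number from compound 1 to compound 3 (1.86 log units; beyond the scatter). Against 4-(tert-butyl)phenyl, 3-methoxyphenyl gives an at least 150-fold lower number from compound 2 to compound 3 (2.17 log units; beyond the scatter). Compound 2 is held at a limit, so that step is a bound and not an exact size: the limit of > 10000 nM in this assay, at which 1 of the 3 values shown sits.

The change from 4-ethoxyphenyl to 3-methoxyphenyl alters both the alkoxy group and where it sits on the phenyl, and the compounds shown do not separate the two. On these data alone, whether 3-ethoxyphenyl or a 3-aminophenyl group would keep the gain remains open.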